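The source may report more compounds than this note shows. Statements on the series, on what has been measured and on what is new or still open speak of the compounds shown alone.

Compound 1 `CC(=O)Oc1ccc(-c2ccc(F)cc2F)cc1C(=O)O`: 0%
Compound 2 `CC(=O)Oc1ccc(-c2ccc(F)cc2F)cc1C(=O)Nc1ccccc1C`: 12.3%
Compound 3 `CC(=O)Oc1ccc(-c2ccc(F)cc2F)cc1C(=O)Nc1cccc(C)c1`: 19%

In a functional assay on the whole organism (strain Kunming) for inhibition, with Mus musculus as the target, in the writhing test, at a dose of 40 mg/kg by the oral route (a lower number here means less inhibition, a higher number more inhibition at the dose given (going by the name of the read-out)), compound 3 gives 19%, the highest of the three numbers. The nearest is compound 2, which gives 12.3%; that gap, a number 6.7 percentage points higher from compound 2 to compound 3 (within the scatter), is within the scatter, so the two cannot be ordered. Compound 1, with hydroxy on the carbonyl carbon, gives 0%, and both amides stand beyond the scatter above it: a number 12.3 percentage points higher from compound 1 to compound 2 (beyond the scatter) and a number 19 percentage points higher from compound 1 to compound 3 (beyond the scatter).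

Compound 4 `CC(=O)Oc1ccc(-c2ccc(F)cc2F)cc1C(=O)Nc1ccccc1Cl` differs from compound 3 in one place: 2-chlorophenyl in place of 3-methylphenyl on an amide-type nitrogen. Within the data shown here, no measured step exchanges a methyl for a chlorine on this ring. The step that comes closest is a number 6.7 percentage points higher from compound 2 to compound 3 (within the scatter), in which the methyl was moved on the same ring without a change beyond the scatter. Together with a number 12.3 percentage points higher from compound 1 to compound 2 (beyond the scatter) and a number 19 percentage points higher from compound 1 to compound 3 (beyond the scatter), this suggests that the presence of the amide carries most of the effect seen so far and the substituent on the ring less. For the step from compound 3 to compound 4 no change beyond the scatter is therefore expected: a number 5 percentage points lower from compound 3 to compound 4 (within the scatter). Compound 4 is estimated to give 14% in this assay, within a range from 2% to 28%.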

Compound 4, a percentage reported as inhibition, in the whole organism at one dose (the size of the read-out at that dose, not a potency): 11.7%
For compound 4 the middle estimate is 2.3 percentage points above the measured one, within the range that was stated.
By their numbers in this assay, from the lowest: compound 1; then compounds 4, 2 and 3 (each within the scatter of the next).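

Chloro in place of methyl on an aromatic carbon, the first direct exchange of these two groups on this ring, gives a number 0.6 percentage points lower from compound 2 to compound 4 (within the scatter) in this assay, so at this position the two groups cannot be told apart. The step with 2-chlorophenyl in place of 3-methylphenyl on the amide-type nitrogen, which alters both the group and its ring position, gives a number 7.3 percentage points lower from compound 3 to compound 4 (within the scatter) and likewise shows no separation, while a number 11.7 percentage points higher from compound 1 to compound 4 (beyond the scatter) adds a third amide that stands clear of the acid, with no compound shown going against this; together these results place the measurable difference with the replacement of hydroxy on the carbonyl carbon, not with the choice among these three aryl groups. No measured evidence is available to explain these results.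

The compounds shown leave open whether 3-chlorophenyl, a methoxyphenyl or a trifluoromethylphenyl group on this nitrogen would read differently from these three aryl groups. They also leave open whether the aromatic ring is needed at all, which an amide bearing a butyl chain on the nitrogen would test.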